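This account rests on a few compounds, and the source may have more. Where it says the series, first, only, none or still open, it means among the compounds named here.

Compound 2 `O=C(N/N=C/c1ccccc1O)c1c[nH]c2ccc(Cl)cc2c1=O` gives 1110000 nM in an ADME assay on Vero cells (Chlorocebus sabaeus) for cytotoxicity, read by MTT assay (on this read-out higher numbers stand for lower toxicity in this test and lower numbers for higher toxicity in this test), the higher of the two numbers in hand. Compound 1 `O=C(N/N=C/c1ccccc1O)c1c[nH]c2ccccc2c1=O` gives 502000 nM in this assay. Among the compounds with values here, the only measured step, a 2.2-fold higher number from compound 1 to compound 2 (0.34 log units; beyond the scatter), came with chloro in place of hydrogen on an aromatic carbon. Compound 3 `O=C(N/N=C/c1ccccc1O)c1c[nH]c2ccc(Br)cc2c1=O` differs from compound 2 by bromo in place of chloro on an aromatic carbon. Within the data shown here, no measured step swaps one halogen for another, so that step is the nearest guide, and a shift of at most modest size, if any, is expected in this assay for compound 3. Compound 3 is estimated at 1200000 nM, with a range of 500000 nM to 3000000 nM, an expected step of a 1.1-fold higher number from compound 2 to compound 3 (0.03 log units; within the scatter).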

Compound 3, half-maximal cytotoxic concentration: 443000 nM
Compound 3: middle estimate off by 2.7-fold (0.43 log units), on the high side; measured number below the stated range.
By their numbers in this assay, from the lowest: compounds 3 and 1 (each within the scatter of the next); then compound 2.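

In this assay, swapping one halogen for the other at this aromatic carbon is not neutral: the change gives a 2.5-fold lower number from compound 2 to compound 3 (0.40 log units; beyond the scatter), so the higher number seen with chloro does not carry over to bromo. Bromo in place of hydrogen gives a 1.1-fold lower number from compound 1 to compound 3 (0.05 log units; within the scatter), so on these compounds a higher number goes with chloro alone, not with halogen as such. No supporting data bear on why the two halogens differ.

Going by these compounds, whether fluoro, methoxy or an amine at this carbon would follow chloro or bromo remains open. So does whether the chloro step holds with other changes to the shared core.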